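A few compounds are considered here, and "the series" means these few. Any claim that something is new, unique, unknown or untested is made for them only; others in the source may bear on it.

Two compounds share one core and differ only in the ring on the amide-type nitrogen. Among the measured compounds shown here, in an assay on HEK293 cells for binding affinity to Neuropeptide Y receptor type 5 (Homo sapiens), read by radioligand binding (a higher number here means a weaker inhibitor, a lower number a stronger inhibitor), compound 2 `Cc1cc(C(=O)Nc2cccc(I)c2)nn1-c1cccc(C(F)(F)F)c1` gives 670 nM, the lowest of the two numbers so far, and compound 1 `Cc1cc(C(=O)Nc2ccc(F)cc2)nn1-c1cccc(C(F)(F)F)c1` gives 800 nM; the step of a 1.2-fold lower number from compound 1 to compound 2 (0.08 log units; within the scatter) lies within the scatter. Compound 3 `Cc1cc(C(=O)Nc2ccc(Cl)cc2)nn1-c1cccc(C(F)(F)F)c1` differs from compound 2 by 4-chlorophenyl in place of 3-iodophenyl on an amide-type nitrogen. For the measured compounds named here, only that one halogen swap on this ring bears on the change, and it moved nothing beyond the scatter, so for compound 3 no step beyond the scatter is expected, a 1.1-fold higher number from compound 2 to compound 3 (0.05 log units; within the scatter), giving an estimated 750 nM in this assay, between 350 nM and 1600 nM.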

Compound 3, half-maximal inhibitory concentration: > 1000 nM
Compound 3: only a limit was reported; the forecaster's own chance of this, stated with the estimate: 5%; middle value at least 1.3-fold (0.12 log units) away from the limit.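

Compound 3 carries only a limit, not a number: the limit of > 1000 nM in this assay, at which 1 of the 3 values shown sits. Read against it, the steps are floors: an at least 1.4-fold higher number from compound 2 to compound 3 (0.17 log units; that floor lies within the scatter) and an at least 1.2-fold higher number from compound 1 to compound 3 (0.09 log units; that floor lies within the scatter). From the compounds shown here alone, both floors lie within the scatter, and the true size of either step stays unknown, which makes 4-chlorophenyl the first ring here whose reading has no upper end: it may sit close to the other two or far from them. Still open, going by these compounds, is how this ring would read with an amine or a carboxylic acid in place of the halogen.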